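Substituting the silyl ether on the triazole nitrogen chain

This account rests on a few compounds, and the source may have more. Where it says the series, first, only, none or still open, it means among the compounds named here.

Compound 2 `Cn1nc(Cc2nnc(SCCCCCCCC(=O)Nc3ccc(Cl)cc3Cl)n2CCCO[Si](C)(C)C(C)(C)C)c2ccccc2c1=O` is the starting point here. In an assay on NK92 cells for inhibition of interleukin-15 (Homo sapiens), read by AlphaScreen, with stated times of 30 min and 1 h (on this read-out higher numbers stand for weaker inhibition and lower numbers for stronger inhibition), compound 2 reaches only the limit > 30000 nM, so no number is known for it, only that it sits at the limit (the limit of > 30000 nM in this assay, at which 1 of the 2 values shown sits). Compound 1 `Cn1nc(Cc2nnc(SCCCCCCCC(=O)Nc3ccc(Cl)cc3Cl)[nH]2)c2ccccc2c1=O` differs from it only by a hydrogen on that aromatic nitrogen, and in this assay compound 1 gives 280 nM. For the measured compounds named here, the step of an at least 100-fold higher number from compound 1 to compound 2 (2.02 log units; beyond the scatter) is therefore the one measured change that bears on what follows.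

Compound 3 `CN(C)CCCn1c(Cc2nn(C)c(=O)c3ccccc23)nnc1SCCCCCCCC(=O)Nc1ccc(Cl)cc1Cl` keeps the chain on the aromatic nitrogen but changes its end: a group of 3 heavy atoms (2 carbon, 1 nitrogen; no ring) in place of a group of 8 heavy atoms (6 carbon, 1 oxygen, 1 silicon; no ring), on a saturated chain carbon, three bonds along the chain from an aromatic nitrogen. Since the chain on the aromatic nitrogen remains, and the step of an at least 100-fold higher number from compound 1 to compound 2 (2.02 log units; beyond the scatter) showed how much that chain cost, compound 3 is expected to stay weak, though the dimethylamino end may recover part of the loss. The step from compound 2 to compound 3 is accordingly estimated as an at least 2.5-fold lower number from compound 2 to compound 3 (0.39 log units; beyond the scatter). In this assay compound 3 is expected to give about 12000 nM, within 2000 nM to 40000 nM.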

Compound 3, half-maximal inhibitory concentration: > 30000 nM
Compound 3 ended at the assay's limit; the forecaster's own chance of this, stated with the estimate: 45%; middle value at least 2.5-fold (0.39 log units) away from the limit.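

Putting 3-(dimethylamino)propyl in place of the hydrogen on the aromatic nitrogen gives an at least 100-fold higher number from compound 1 to compound 3 (2.02 log units; beyond the scatter) in this assay, so the loss at this position is not tied to the silyl ether end alone. With a different end on the same chain, the result is again a limit of the assay and not a number, so the steps between the two chain ends cannot be read and the two ends cannot be ranked against each other. Both substituted compounds stop at the same place on the read-out, and only compound 1, without a chain on that nitrogen, keeps a measurable value: the limit of > 30000 nM in this assay, at which 2 of the 3 values shown sit.

On these data alone, whether a much smaller group on that aromatic nitrogen, such as methyl or ethyl, would keep a measurable value remains open. Also open, as far as these compounds go, is whether a propyl chain ending in a hydroxyl or a carboxylic acid would come back within the range of the assay, or would stay at the limit as the silyl ether and dimethylamino ends do.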